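A few compounds are considered here, and "the series" means these few. Any claim that something is new, unique, unknown or untested is made for them only; others in the source may bear on it.

Within the data shown here, compound 1 `Nc1ncnc2c1ncn2/C=C1\C[C@H]1[C@H](O)CO` gives 194000 nM in an ADME assay on HFF cells (Homo sapiens) for cytotoxicity, read by neutral red uptake (a higher number here means that more compound is tolerated, a lower number that less compound is tolerated), the only number so far. Compound 2 `Nc1nc2c(ncn2/C=C2/C[C@@H]2[C@@H](O)CO)c(=O)[nH]1` gives > 300000 nM, which is a limit. Compound 3 `Nc1nc2c(ncn2/C=C2/C[C@H]2[C@H](O)CO)c(=O)[nH]1` gives > 300000 nM, also a limit. Compound 4 `Nc1ncnc2c1ncn2/C=C1\C[C@H]1[C@@H](O)CO` departs from compound 1 as follows: the two compounds have the same atoms and bonds and differ only in configuration as drawn: 1 of 3 stereo elements differ; a stereocentre at a saturated chain carbon is drawn S in compound 1 and R in compound 4. Among the measured compounds shown here, the one measured step that bears on this change is a step that the two limits leave unreadable from compound 2 to compound 3, which rests on (the fact that compounds 2 and 3 differ only in the configuration as drawn). That step gives no size to carry over because of the limit of > 300000 nM in this assay, at which 2 of the 3 values shown sit. No step beyond the scatter is therefore expected, and the expected change is a 1.0-fold higher number from compound 1 to compound 4 (0.01 log units; within the scatter), with no direction favoured. Compound 4 is estimated at 200000 nM, with an expected range of 100000 nM to 300000 nM.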

Compound 4, half-maximal cytotoxic concentration: 264000 nM
Compound 4: middle estimate off by 1.3-fold (0.12 log units), on the low side; measured number inside the range.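

In this assay, redrawing the saturated chain carbon from S to R gives a 1.4-fold higher number from compound 1 to compound 4 (0.13 log units; within the scatter), the first readable size for a configuration change in this series. Compound 2 and compound 3 gave no such size, as both values are limits. For the core of compound 1, this single stereocentre therefore shows no change beyond the scatter. Going by these compounds, the effect of redrawing the saturated ring carbon alone remains open. So does the reading for a carboxylic acid or a longer chain at the saturated chain carbon.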